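Extending the chain on the aromatic nitrogen of compound 1

This account rests on a few compounds, and the source may have more. Where it says the series, first, only, none or still open, it means among the compounds named here.

compound 1, `CCn1nc(C)c2c(C)cc(=O)oc21`: 24.9 mg/kg
compound 2, `CCOC(=O)Cc1nn(C)c2oc(=O)cc(C)c12`: > 100 mg/kg

Within the data shown here, in a functional assay on the whole organism with Mus musculus as the target, in the writhing test (a lower number here means that less compound is needed, a higher number that more compound is needed for the effect), compound 1 gives 24.9 mg/kg, the only number among the two values shown. Compound 2 reaches only > 100 mg/kg, which is a limit of the assay and not a number (the limit of > 100 mg/kg in this assay, at which 1 of the 2 values shown sits). Compound 1 therefore stands alone as the measured reference.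

Compound 3 `CCCCn1nc(C)c2c(C)cc(=O)oc21` differs from compound 1 by ethyl in place of hydrogen on a saturated chain carbon, two bonds along the chain from an aromatic nitrogen. Among the measured compounds shown here, no step between measured compounds is available to guide the size of this change. The step is expected to stay small, a 1.2-fold higher number from compound 1 to compound 3 (0.08 log units; within the scatter), not beyond the usual scatter. Compound 3 is estimated at 30 mg/kg, within 12 mg/kg to 80 mg/kg.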

Compound 3, dose for half-maximal effect: > 100 mg/kg
Compound 3 ended at the assay's limit; the forecaster's own chance of this, stated with the estimate: 15%; middle value at least 3.3-fold (0.52 log units) from the limit.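

Ethyl in place of hydrogen on a saturated chain carbon, two bonds along the chain from an aromatic nitrogen, gives an at least 4.0-fold higher number from compound 1 to compound 3 (0.60 log units; beyond the scatter) in this assay. This position is therefore sensitive to chain length, at least for the change from ethyl to butyl. The value of compound 3 is a limit and not a number: the limit of > 100 mg/kg in this assay, at which 2 of the 3 values shown sit.

Going by these compounds, the true size of the step remains open. So does whether propyl, or an amine or carboxylic acid on this chain, would retain the effect of compound 1.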